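The source may report more compounds than this note shows. Statements on the series, on what has been measured and on what is new or still open speak of the compounds shown alone.

Measured so far in a functional assay on SGC-7901 cells (Homo sapiens) for inhibition, read by MTT assay, with a stated time of 48 h; a lower number here means a stronger inhibitor, a higher number a weaker inhibitor:

Compound 1 `Cc1nnsc1CO/N=C/c1c(C)nn(C)c1Oc1ccc(F)cc1` sits at the limit > 50000 nM of this assay.
Compound 2 `Cc1ccc(Oc2c(/C=N/OCc3snnc3C)c(C)nn2C)cc1` gives 12800 nM.
Compound 3 `Cc1nnsc1CO/N=C/c1c(C)nn(C)c1Oc1cc(F)cc(F)c1` gives 9410 nM.

Compound 2 and compound 3 lie within the usual scatter of each other, as a 1.4-fold lower number from compound 2 to compound 3 (0.13 log units; within the scatter) shows. Compound 1 stands apart only as a limit (the limit of > 50000 nM in this assay, at which 1 of the 3 values shown sits); against it, an at least 3.9-fold lower number from compound 1 to compound 2 (0.59 log units; beyond the scatter) and an at least 5.3-fold lower number from compound 1 to compound 3 (0.72 log units; beyond the scatter) are both beyond the scatter, with the methylphenyl and the difluorophenyl ethers each giving a real number where the fluorophenyl ether gave none.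

Compound 4 `CCc1nnsc1CO/N=C/c1c(C)nn(C)c1Oc1ccc(C)cc1` differs from compound 2 by methyl in place of hydrogen on a saturated chain carbon bound to an aromatic carbon. None of the measured steps touches this part of the molecule: all three concern the aryl ether on the shared core, so nothing shown bears directly on lengthening the chain on the thiadiazole. With no evidence either way, the working expectation is a step from compound 2 to compound 4 of a 1.1-fold lower number from compound 2 to compound 4 (0.03 log units; within the scatter), that is none beyond the scatter. Compound 4 is therefore estimated in this assay at 12000 nM, with a range from 4500 nM to 35000 nM.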

Compound 4, half-maximal inhibitory concentration: 19800 nM
Compound 4: the middle estimate sits 1.7-fold (0.22 log units) below what was measured; the measured number falls inside the stated range.
By their numbers in this assay, from the lowest: compounds 3, 2 and 4 (each within the scatter of the next, the first and the last beyond it). At a limit, above all of these: compound 1.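

In this assay, the first change away from the aryl ether gives a 1.5-fold higher number from compound 2 to compound 4 (0.19 log units; within the scatter). On the 4-methylphenyl ether, going from 4-methyl-1,2,3-thiadiazol-5-yl to 4-ethyl-1,2,3-thiadiazol-5-yl therefore produces no shift beyond the scatter, so this one pair gives no sign that the added methyl matters at this position. Nothing at hand offers a reason for this result.

On these data alone, whether the same change behaves alike on the 3,5-difluorophenyl ether remains open, as this position has been read on the 4-methylphenyl ether only. Also open, as far as these compounds go, is whether a longer chain such as propyl, or a more different group such as an amine or a carboxylic acid on the chain, would move the number beyond the scatter.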